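A few compounds are considered here, and "the series" means these few. Any claim that something is new, unique, unknown or untested is made for them only; others in the source may bear on it.

Working notes on the aryl ester series built on a shared core.

Compound 1 `COc1ccc(C(=O)Oc2cc3c(cc2C)[C@@H](C(C)C)CC=C3C)cc1` carries a methoxy-bearing benzoate; in a functional assay on U-251 cells (Homo sapiens) for antiproliferative activity, read by sulforhodamine B assay, with a stated time of 48 h, tested at 50 uM (a lower number here means less inhibition, a higher number more inhibition at the concentration tested (going by the name of the read-out)), compound 1 gives 37%. Among the measured compounds shown here, compound 2 `CC1=CC[C@H](C(C)C)c2cc(C)c(OC(=O)c3ccc(Cl)cc3)cc21` gives 25.6% in this assay, and the one single-point change measured so far, a number 11.4 percentage points lower from compound 1 to compound 2 (beyond the scatter), shows that swapping one substituent on the ester ring for another can move the number by a modest amount. Compound 3 `CC1=CC[C@H](C(C)C)c2cc(C)c(OC(=O)c3cccc(C(F)(F)F)c3)cc21` gives 29.3% in this assay and stands second highest of the three numbers; its gap to compound 2 and its gap to compound 1 both lie within the scatter.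

Compound 4 `CC1=CC[C@H](C(C)C)c2cc(C)c(OC(=O)c3cccc([N+](=O)[O-])c3)cc21` is the next member: nitro in place of trifluoromethyl on an aromatic carbon. For the measured compounds named here, no measured step pairs trifluoromethyl against nitro, so only the size of the step from compound 1 to compound 2 offers a guide, and it was modest. The expectation for this assay is therefore a step in either direction no larger than that, most likely within the scatter, so that compound 4 is estimated at 29% with a range of 16% to 42%, and the expected step of a number 0.3 percentage points lower from compound 3 to compound 4 (within the scatter) is small.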

Compound 4, a percentage reported as inhibition, at one concentration (the size of the read-out at that concentration, not a potency): 44%
For compound 4 the middle estimate is 15 percentage points below the measured one; the measured number lies above the stated range.
By their numbers in this assay, from the lowest: compounds 2, 3, 1 and 4 (each within the scatter of the next, the first and the last beyond it).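

In this assay, exchanging trifluoromethyl for nitro on this aromatic carbon, meta to a large group, gives a step beyond the scatter (a number 14.7 percentage points higher from compound 3 to compound 4 (beyond the scatter)), the first measured at this position. The exchange of the whole aryl group also separates the 3-nitrophenyl ester from the 4-chlorophenyl ester (a number 18.4 percentage points higher from compound 2 to compound 4 (beyond the scatter)), while the 3-nitrophenyl and 4-methoxyphenyl esters are not separated (a number 7 percentage points higher from compound 1 to compound 4 (within the scatter)). No measurement on hand bears on why the nitro compound differs from its trifluoromethyl and chloro counterparts.

Among the compounds shown here, only two groups are compared at this position, so it remains open whether an amine or a carboxylic acid on the same aromatic carbon would give a number nearer that of compound 3 or that of compound 4. Going by these compounds, each number is a reading at one concentration, and the relative potency of these esters also remains open.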